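Adding a methoxy to the benzylamine of the shared core

A few compounds are considered here, and "the series" means these few. Any claim that something is new, unique, unknown or untested is made for them only; others in the source may bear on it.

Compound 1, `Nc1cc(N)c2nc(-c3ccccc3)c(NCc3ccc(Cl)c(Cl)c3)nc2c1`, carries a 3,4-dichlorophenyl on the chain carbon bound to the ring nitrogen. In a functional assay on SK-OV-3 cells (Homo sapiens) for inhibition, read by sulforhodamine B assay, with a stated time of 48 h (on this read-out lower numbers stand for higher toxicity in this test and higher numbers for lower toxicity in this test), compound 1 gives 69200 nM. Compound 2, `COc1ccc(CNc2nc3cc(N)cc(N)c3nc2-c2ccccc2)cc1OC`, differs in that a 3,4-dimethoxyphenyl takes the place of the 3,4-dichlorophenyl. In this assay compound 2 reaches only a limit, < 100000 nM. Compound 3, `CCOC(=O)[C@H](CCC(=O)O)NC(=O)c1ccc(Sc2nc3cc(N)cc(N)c3nc2-c2ccccc2)cc1`, also reaches only a limit in this assay, < 100000 nM. Among the measured compounds shown here, compound 2 thus stands at the limit where two of the three measured values sit, and the one step that leads to it, a step that the limit leaves unreadable from compound 1 to compound 2, cannot be read in size because of the limit (the limit of < 100000 nM in this assay, at which 2 of the 3 values shown sit).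

Compound 4, `COc1cc(CNc2nc3cc(N)cc(N)c3nc2-c2ccccc2)cc(OC)c1OC`, adds to compound 2 a third methoxy: methoxy in place of hydrogen on an aromatic carbon. For the measured compounds named here, no measured step touches that kind of change, and the step into compound 2 itself is unreadable, so nothing here tells how large a move to expect in this assay or in which direction. The estimate therefore keeps compound 4 close to where compound 2 stands, expecting a step that the limit leaves unreadable from compound 2 to compound 4. Compound 4 is expected to show about 80000 nM, with a range from 30000 nM to 150000 nM.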

Compound 4, concentration lethal to 50% of the cells: 36300 nM
Beside the measured number, compound 4's estimate is 2.2-fold (0.34 log units) above it; the range from low to high includes it.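

The step from compound 2 to compound 4 cannot be read in size, because compound 2 has only a limit and no number in this assay: the limit of < 100000 nM in this assay, at which 2 of the 4 values shown sit.

The compounds shown leave open how far, and in which direction, adding the methoxy on the aromatic carbon moves the read-out in this assay.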